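This account rests on a few compounds, and the source may have more. Where it says the series, first, only, none or still open, it means among the compounds named here.

Working notes on the urea pair. In an ADME assay on the whole organism with Oryza sativa as the target, tested at 0.1 uM (a higher number here means a weaker effect of the compound at the concentration tested, a lower number a stronger effect), compound 1 `CCc1ccc(NC(=O)N[C@@H](C)c2ccccc2)cc1` gives 99%. In this assay, for the measured compounds named here, compound 2 `C[C@@H](NC(=O)Nc1ccc(C(F)(F)F)cc1)c1ccccc1` gives 93%; its number and that of compound 1 lie within the scatter of each other, and compound 1 is the only comparison available. The next step goes from compound 2 to compound 3 `C[C@H](NC(=O)Nc1ccc(C(F)(F)F)cc1)c1ccccc1`. The change is the two compounds have the same atoms and bonds and differ only in configuration as drawn: 1 of 1 stereo elements differ; a stereocentre at a saturated chain carbon is drawn R in compound 2 and S in compound 3. Going by the values given here, no measured step exists between these two; with one stereo element drawn differently and nothing else changed, the expected step is a number 3 percentage points lower from compound 2 to compound 3 (within the scatter), none beyond the scatter. Compound 3 is expected to give about 90%, estimated between 72% and 100%.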

Compound 3, a percentage reported as activity, at one concentration (the size of the read-out at that concentration, not a potency): 94%
Compound 3: middle estimate off by 4 percentage points, on the low side, and the stated range covers the measured number.
By their numbers in this assay, from the lowest: compounds 2, 3 and 1 (each within the scatter of the next).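

In this assay, the stereocentre at the saturated chain carbon gives a number 1 percentage points higher from compound 2 to compound 3 (within the scatter), so R and S as drawn are not told apart at this position, and the comparison isolates that centre: the fact that compounds 2 and 3 differ only in the configuration as drawn With S drawn, trifluoromethyl in place of ethyl on an aromatic carbon gives a number 5 percentage points lower from compound 1 to compound 3 (within the scatter), so this exchange is also not resolved.

Open, as far as these compounds go, is whether an amine or a carboxylic acid on that aromatic carbon would give a step beyond the scatter. Also open, from the compounds shown here alone, is whether configuration would stay without a resolved effect alongside such a group.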